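The source may report more compounds than this note shows. Statements on the series, on what has been measured and on what is new or still open speak of the compounds shown alone.

Working notes on the series. In a functional assay on MCF7 cells (Homo sapiens) for antiproliferative activity, read by MTT assay, with a stated time of 72 h (on this read-out lower numbers stand for stronger inhibition and higher numbers for weaker inhibition), compound 1 `COc1cc(-n2cnc3ccc(-c4ccccc4Cl)cc32)cc(OC)c1OC` gives > 10000 nM, which is a limit of the assay and not a number. Compound 2 `COc1cc(-n2cnc3ccc(-c4ccc(C(C)=O)cc4)cc32)cc(OC)c1OC` gives 1540 nM and compound 3 `COc1cc(-n2cnc3ccc(-c4cccc(F)c4)cc32)cc(OC)c1OC` gives 2350 nM, and these two values lie within the scatter of each other: a 1.5-fold higher number from compound 2 to compound 3 (0.18 log units; within the scatter). Compound 4 `COc1cc(-n2cnc3ccc(-c4ccc(O)cc4)cc32)cc(OC)c1OC` carries 4-hydroxyphenyl in place of 3-fluorophenyl on an aromatic carbon. The two steps away from 2-chlorophenyl were larger, an at least 6.4-fold lower number from compound 1 to compound 2 (0.81 log units; beyond the scatter) and an at least 4.2-fold lower number from compound 1 to compound 3 (0.62 log units; beyond the scatter), but compound 4 does not carry that group. The exchange between compound 2 and compound 3 is the closest guide, so no change beyond the scatter is expected in this assay. The estimated step is a 1.2-fold lower number from compound 3 to compound 4 (0.07 log units; within the scatter). For compound 4 the expected value is 2000 nM, with an estimated range of 700 nM to 6000 nM.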

Compound 4, half-maximal inhibitory concentration: 4160 nM
The estimate for compound 4 lay 2.1-fold (0.32 log units) below the measured number; the range from low to high includes it.
By their numbers in this assay, from the lowest: compounds 2, 3 and 4 (each within the scatter of the next, the first and the last beyond it). At a limit, above all of these: compound 1.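

In this assay, 4-hydroxyphenyl brings a hydrogen-bond donor that 3-fluorophenyl lacks, yet the two cannot be separated: a 1.8-fold higher number from compound 3 to compound 4 (0.25 log units; within the scatter). The same group does separate from the acetyl group of compound 2, a 2.7-fold higher number from compound 2 to compound 4 (0.43 log units; beyond the scatter), so a first modest gap appears among the groups with numerical values. With an at least 2.4-fold lower number from compound 1 to compound 4 (0.38 log units; beyond the scatter), 2-chlorophenyl remains the only group shown whose value is a limit and not a number: the limit of > 10000 nM in this assay, at which 1 of the 4 values shown sits.

Left open is whether an amine or a carboxylic acid on the same phenyl ring would track compound 2 or compound 4.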